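The compounds below may be only part of what the source reports. "The series", "measured", "known", "first", "only" and "open" are said of these compounds alone.

Measured in an ADME assay on KB cells (Homo sapiens) for cytotoxicity, read by MTT assay, with a stated time of 72 h; a higher number here means a weaker inhibitor, a lower number a stronger inhibitor:

- Compound 1 `COc1ccc(C2=C(c3cc(OC)c(OC)c(OC)c3)C(=O)C(OC(C)=O)C2)cc1OC(C)C`: > 100 ug/mL (a limit of the assay, not a number)
- Compound 2 `COc1ccc(C2=C(c3cc(OC)c(OC)c(OC)c3)C(=O)C(OC(C)=O)C2)cc1`: 72 ug/mL
- Compound 3 `COc1ccc(C2=C(c3cc(OC)c(OC)c(OC)c3)C(=O)C(O[SiH2]C(C)(C)C)C2)cc1`: 7 ug/mL

Compound 3 holds the lowest number of the three, and a lower number means a stronger inhibitor. The nearest number belongs to compound 2, at 72 ug/mL, and a 10-fold lower number from compound 2 to compound 3 (1.01 log units; beyond the scatter) is a large gap.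

Compound 4 `COc1ccc(C2=C(c3cc(OC)c(OC)c(OC)c3)C(=O)C(O[SiH2]C(C)(C)C)C2)cc1OC(C)C` differs from compound 3 by one change: isopropoxy in place of hydrogen on an aromatic carbon.

Among the compounds with values here, the one measured step that bears on this change runs the opposite way: an at least 1.3-fold lower number from compound 1 to compound 2 (0.14 log units; that floor lies within the scatter). From the compounds shown here alone, it gives only a floor, set by the limit of > 100 ug/mL in this assay, at which 1 of the 3 values shown sits, so its true size is unknown. Compounds 1 and 2 also carry a different group on an oxygen on a saturated carbon, so the step may not carry over exactly.

In this assay, a modest rise in the number is therefore expected. The expected change is a 2.1-fold higher number from compound 3 to compound 4 (0.33 log units; beyond the scatter). For compound 4 the estimated value is 15 ug/mL, with an expected range of 6 ug/mL to 50 ug/mL.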

Compound 4, half-maximal inhibitory concentration: 7.5 ug/mL
Estimate against measurement, compound 4: 2.0-fold (0.30 log units) above; the measured number falls inside the stated range.
By their numbers in this assay, from the lowest: compounds 3 and 4 (each within the scatter of the next); then compound 2. At a limit, above all of these: compound 1.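

In this assay, going from 4-methoxyphenyl to 3-isopropoxy-4-methoxyphenyl on the silicon-bearing core gives a 1.1-fold higher number from compound 3 to compound 4 (0.03 log units; within the scatter), so at this place the added isopropoxy leaves the number unchanged within the scatter. Compound 1 stands at > 100 ug/mL, which is a limit of the assay and not a number. With isopropoxy in place on both compounds, the silicon-bearing group on the oxygen gives an at least 13-fold lower number from compound 1 to compound 4 (1.12 log units; beyond the scatter), so the large step seen without isopropoxy also appears with it: the same change on two cores in this assay, a 10-fold lower number (1.01 log units; beyond the scatter) from compound 2 to compound 3 and an at least 13-fold lower number (1.12 log units; beyond the scatter) from compound 1 to compound 4; the limit leaves it open whether they differ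

Whether isopropoxy has the same effect on the two cores remains unsettled: the same change on two cores in this assay, an at least 1.3-fold lower number (0.14 log units; that floor lies within the scatter) from compound 1 to compound 2 and a 1.1-fold lower number (0.03 log units; within the scatter) from compound 4 to compound 3; the limit leaves it open whether they differ The compounds shown also leave open what a shorter ethoxy group or an amine would do at this same place.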